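Benzyl in place of methyl on selenium: compound 4 expected

The source may hold more compounds than are shown below. What is called first, only, known or untested is meant among the compounds shown, and "the series" means these compounds.

Compound 1 `C[Se]/C(=N\C(=O)c1cccs1)NC(=O)c1cccs1` — > 100000 nM
Compound 2 `C[Se]/C(=N\C(=O)c1sccc1Cl)NC(=O)c1sccc1Cl` — > 100000 nM
Compound 3 `CS/C(=N\C(=O)c1csc([N+](=O)[O-])c1)NC(=O)c1csc([N+](=O)[O-])c1` — > 100000 nM

In a functional assay on MCF7 cells (Homo sapiens) for cytotoxicity, read by MTT assay, with a stated time of 72 h (on this read-out higher numbers stand for lower toxicity in this test and lower numbers for higher toxicity in this test), compound 1 gives > 100000 nM, which is a limit of the test and not a number. Compound 2 likewise shows only a limit, > 100000 nM. Compound 3 also shows only a limit, > 100000 nM. Compound 1 thus stands at the edge of what this assay reports (the limit of > 100000 nM in this assay, at which 3 of the 3 values shown sit). Compound 4 `O=C(/N=C(/NC(=O)c1cccs1)[Se]Cc1ccccc1)c1cccs1` differs from compound 1 by phenyl in place of hydrogen on a saturated chain carbon bound to a selenium atom. Among the compounds with values here, no step between two measured compounds is known, so there is nothing to set the size of this change against. Compound 4 is expected to show a step of a number no higher from compound 1 to compound 4 (the limit leaves the size open) of none beyond the scatter. In this assay compound 4 is estimated at 100000 nM, between 30000 nM and 300000 nM.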

Compound 4, concentration lethal to 50% of the cells: > 100000 nM
Compound 4: only a limit was reported (the forecaster's own chance of this, stated with the estimate: 80%); the middle value lies on the limit itself.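

Within the data shown here, compound 1 and compound 4 both give only a limit of the test, so no step between them can be read: the limit of > 100000 nM in this assay, at which 4 of the 4 values shown sit. The compounds shown leave open how far beyond that limit each lies in this assay, and whether phenyl in place of hydrogen changes anything.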